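A Sulfamoylphenyl Variant of a Series Held at the Limit

A few compounds are considered here, and "the series" means these few. Any claim that something is new, unique, unknown or untested is made for them only; others in the source may bear on it.

Compound 3 `N#CC1=C(N)Oc2c(c3nc4ccccc4nc3c3ccccc23)C12C(=O)N(Cc1cnnn1-c1ccc([N+](=O)[O-])cc1)c1ccccc12` stands at the ceiling of the measurement: in a functional assay on A549 cells (Homo sapiens) for antiproliferative activity, read by MTT assay, with a stated time of 48 h (on this read-out higher numbers stand for weaker inhibition and lower numbers for stronger inhibition), compound 3 gives > 50000 nM, which is a limit and not a number. Compound 2 `N#CC1=C(N)Oc2c(c3nc4ccccc4nc3c3ccccc23)C12C(=O)N(Cc1cnnn1-c1cccc(Br)c1)c1ccccc12` likewise returns only a limit, > 50000 nM, in this assay. Among the measured compounds shown here, compound 1 `Cc1cccc(-n2nncc2CN2C(=O)C3(C(C#N)=C(N)Oc4c3c3nc5ccccc5nc3c3ccccc43)c3ccccc32)c1` is the single compound with a number, 39600 nM in this assay. The shared core is varied only at the group on the aromatic nitrogen; the step of an at least 1.2-fold higher number from compound 1 to compound 3 (0.10 log units; that floor lies within the scatter) and the step of an at least 1.2-fold higher number from compound 1 to compound 2 (0.10 log units; that floor lies within the scatter) are floors, and the step that the two limits leave unreadable from compound 2 to compound 3 cannot be read, since (the limit of > 50000 nM in this assay, at which 2 of the 3 values shown sit). Compound 4 `N#CC1=C(N)Oc2c(c3nc4ccccc4nc3c3ccccc23)C12C(=O)N(Cc1cnnn1-c1cccc(S(N)(=O)=O)c1)c1ccccc12` carries the change (3-sulfamoylphenyl in place of 4-nitrophenyl on an aromatic nitrogen). With two of three values at a limit, compound 4 is expected to remain near it, so the estimated step of a number no higher from compound 3 to compound 4 (the limit leaves the size open) is small. Compound 4 is estimated at 50000 nM, within 20000 nM to 120000 nM.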

Compound 4, half-maximal inhibitory concentration: 44200 nM
Beside the measured number, compound 4's estimate is 1.1-fold (0.05 log units) above it; the measured number falls inside the stated range.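

In this assay, the 3-sulfamoylphenyl group yields a second measured number in the series rather than another limit. Against the two limits only floors can be read: an at least 1.1-fold lower number from compound 3 to compound 4 (0.05 log units; that floor lies within the scatter) and an at least 1.1-fold lower number from compound 2 to compound 4 (0.05 log units; that floor lies within the scatter). Against the only other number the step is a 1.1-fold higher number from compound 1 to compound 4 (0.05 log units; within the scatter), so sulfamoyl and methyl on this aromatic carbon are not told apart. From the compounds shown here alone, whether any group here can move the number beyond the scatter stays open, as does whether an amine or a carboxylic acid in place of sulfamoyl would do so.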